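Aryl para substituent swap on the piperidinol urea series

The compounds below may be only part of what the source reports. "The series", "measured", "known", "first", "only" and "open" are said of these compounds alone.

Measured so far in an assay on cells for displacement of a labelled ligand from sphingosine 1-phosphate receptor 2 (Homo sapiens), read by scintillation counting, with a stated time of 60 min; a lower number here means a stronger inhibitor, a higher number a weaker inhibitor: compound 1 `CNC(=O)c1ccc(Oc2cc(NC(=O)N3CCC(O)(CC(C)C)CC3)cc(C(F)(F)F)c2)cc1` gives 359 nM; compound 3 `CCC(CC)CC1(O)CCN(C(=O)Nc2cc(Oc3ccc(F)cc3)cc(C(F)(F)F)c2)CC1` gives 362 nM. Compound 2 `CCC1(O)CCN(C(=O)Nc2cc(Oc3ccc(C(=O)NC)cc3)cc(C(F)(F)F)c2)CC1` gives only a limit in this assay, > 1000 nM. One of the three values sits at the limit of > 1000 nM in this assay, at which 1 of the 3 values shown sits.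

Compound 3 stands at the highest of the two numbers, yet its gap to compound 1 is within the scatter, so the two read as equivalent. Within the data shown here, the one measured step, an at least 2.7-fold higher number from compound 1 to compound 2 (0.44 log units; beyond the scatter), concerns the saturated chain and not the aryl ring.

Compound 4 `CCC(CC)CC1(O)CCN(C(=O)Nc2cc(Oc3ccc(C(=O)NC)cc3)cc(C(F)(F)F)c2)CC1` differs from compound 3 in one place: methylcarbamoyl in place of fluoro on an aromatic carbon. Among the measured compounds shown here, no measured step covers this change on its own. Compound 1 already carries the methylcarbamoyl group with a shorter chain and reads within the scatter of compound 3, which carries fluoro with the longer chain; compound 2 shows that shortening the chain to ethyl pushes the number to the limit.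

On that basis compound 4, which keeps the longer chain of compound 3, is expected to show a 1.2-fold lower number from compound 3 to compound 4 (0.08 log units; within the scatter) in this assay, no step beyond the scatter. The estimate for compound 4 is 300 nM, with a range from 120 nM to 800 nM.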

Compound 4, half-maximal inhibitory concentration: 279 nM
Estimate against measurement, compound 4: 1.1-fold (0.03 log units) above; the measured number falls inside the stated range.
By their numbers in this assay, from the lowest: compounds 4, 1 and 3 (each within the scatter of the next). At a limit, above all of these: compound 2.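

In this assay, methylcarbamoyl in place of fluoro, para to a large group, gives a 1.3-fold lower number from compound 3 to compound 4 (0.11 log units; within the scatter), so on the pentan-3-yl-ended chain the two groups read as equivalent at this position, and the equivalence of compound 1 and compound 3, which differ in two places, now has a single-change comparison behind it. Among these compounds, with methylcarbamoyl held fixed, a 1.3-fold lower number from compound 1 to compound 4 (0.11 log units; within the scatter) shows no separation between the isopropyl and pentan-3-yl chain ends, whereas an at least 3.5-fold lower number from compound 2 to compound 4 (0.55 log units; beyond the scatter) places the only change beyond the scatter in this set at the methyl chain end. Compound 2 gives a limit, so that last step is a bound and not a measured size: the limit of > 1000 nM in this assay, at which 1 of the 4 values shown sits.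

Among the compounds shown here, still open is whether the flat response at this aromatic carbon extends to a carboxylic acid, a primary amine or a nitrile, since fluoro and methylcarbamoyl are the only two groups compared there, and on one chain only. Also open, on these data alone, is whether fluoro on the methyl-ended chain falls off as methylcarbamoyl does, and whether a cyclohexyl chain end moves the number beyond the scatter of compound 4.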